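The source may report more compounds than this note shows. Statements on the series, on what has been measured and on what is new or still open speak of the compounds shown alone.

Of the compounds shown here, two built on one shared core have been tested in a functional assay on MCF7 cells (Homo sapiens) for inhibition, read by MTT assay, with a stated time of 3 days; on this read-out lower numbers stand for stronger inhibition and higher numbers for weaker inhibition. Compound 1, `COc1cc(-c2nc3ccccc3s2)ccc1OCC(=O)NNC(=O)CN[C@@H](CS(=O)(=O)O)C(=O)O`, gives 1870 nM in this assay. Compound 2, `CCOC(=O)[C@@H](NCC(=O)NNC(=O)COc1ccc(-c2nc3ccccc3s2)cc1OC)[C@@H](C)CC`, gives 1950 nM in this assay. Going by the values given here, the single measured step, a 1.0-fold higher number from compound 1 to compound 2 (0.02 log units; within the scatter), exchanged the group on the amine nitrogen and left the number essentially where it was, so compound 2 stands within the scatter of compound 1 and neither can be called the stronger of the pair.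

Compound 3, `CCOC(=O)[C@H](CCSC)NCC(=O)NNC(=O)COc1ccc(-c2nc3ccccc3s2)cc1OC`, has not yet been measured. It differs from compound 2 in one place: 2-(methylsulfanyl)ethyl in place of sec-butyl on a saturated chain carbon bound to an amine nitrogen and a carbonyl carbon. This change once more touches the group carried by the amine nitrogen, the same region that the earlier step altered. Because a 1.0-fold higher number from compound 1 to compound 2 (0.02 log units; within the scatter) fell within the scatter, the expectation is that this further swap will likewise leave the number unmoved, with no direction favoured. Compound 3 is therefore estimated at 2000 nM in this assay, with a range from 1000 nM to 4000 nM, an expected step of a 1.0-fold higher number from compound 2 to compound 3 (0.01 log units; within the scatter) that should sit inside the usual scatter.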

Compound 3, half-maximal inhibitory concentration: 1760 nM
Compound 3: the middle estimate sits 1.1-fold (0.06 log units) above what was measured; measured number inside the range.
By their numbers in this assay, from the lowest: compounds 3, 1 and 2 (each within the scatter of the next).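

In this assay, putting 2-(methylsulfanyl)ethyl in place of sec-butyl on the saturated chain carbon bound to an amine nitrogen and a carbonyl carbon gives a 1.1-fold lower number from compound 2 to compound 3 (0.04 log units; within the scatter). This shows that a sulfur atom and a hydrogen-bond acceptor can enter this side chain, with the heavy-atom count unchanged and no ring present, without taking the number outside the scatter. The larger exchange of 1-(ethoxycarbonyl)-3-(methylsulfanyl)propyl for 1-carboxy-2-sulfoethyl on the amine nitrogen gives a 1.1-fold lower number from compound 1 to compound 3 (0.03 log units; within the scatter), so all three different amine-nitrogen groups now sit within the scatter of one another, and no measurement is available to explain this result.

The compounds shown leave open whether a benzyl group or a 4-aminobutyl chain on that same saturated carbon would move the number beyond the scatter. They also leave open whether a shorter group, such as a single methyl, or a much longer alkyl chain would do so, since every step seen so far stays within the scatter and so marks no limit to what this position accepts.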